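Replacing a saturated methylamide chain with a cyclopropyl acrylamide

A few compounds are considered here, and "the series" means these few. Any claim that something is new, unique, unknown or untested is made for them only; others in the source may bear on it.

Measured so far:
compound 1, `CCOC(=O)/C=C/c1ccncc1-c1ccc2[nH]ccc2c1`, > 10000 nM
compound 2, `CNC(=O)CCc1ccncc1-c1ccc2ccccc2c1`, 8980 nM

Of the compounds shown here, two have been tested in a functional assay on MDA-MB-231 cells (Homo sapiens) for inhibition, read by sulforhodamine B assay, with a stated time of 72 h; a higher number here means a weaker inhibitor of growth, a lower number a stronger inhibitor of growth. For compound 1 the result is only a limit of the assay, > 10000 nM, with no number behind it (the limit of > 10000 nM in this assay, at which 1 of the 2 values shown sits). Among the compounds with values here, compound 2 gives the only actual number, 8980 nM, so among the values shown it stands alone, and no step between two measured compounds can be read off.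

Compound 3, `O=C(/C=C/c1ccncc1-c1ccc2ccccc2c1)NC1CC1`, has not yet been measured. It differs from compound 2 in one place: 2-(cyclopropylcarbamoyl)ethenyl in place of 2-(methylcarbamoyl)ethyl on an aromatic carbon. The change keeps the amide but trades its methyl for a cyclopropyl and turns the saturated chain into an ethenyl linker.

Within the data shown here, with no measured step to lean on, the expectation for compound 3 is a step from compound 2 of about a 2.0-fold lower number from compound 2 to compound 3 (0.30 log units; within the scatter), toward stronger inhibition, though only slightly beyond the scatter. Compound 3 is therefore estimated at 4500 nM, between 1200 nM and 18000 nM.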

Compound 3, concentration for 50% growth inhibition: 8420 nM
Beside the measured number, compound 3's estimate is 1.9-fold (0.27 log units) below it; low and high end bracket the measured number.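

In this assay, this change gives a 1.1-fold lower number from compound 2 to compound 3 (0.03 log units; within the scatter), so the two compounds cannot be told apart. At this place, opposite the ring nitrogen, a larger group carrying a three-membered ring and an extra double bond therefore reads the same as 2-(methylcarbamoyl)ethyl, with the amide kept in both. Nothing measured here explains this flat result.

The swap of methyl for cyclopropyl and the swap of the saturated chain for the ethenyl linker arrive together, so this one step cannot show whether each is silent alone or whether the two offset each other. Also open, going by these compounds, is whether a different group at this place, such as an amine, a carboxylic acid or a longer chain, would move the number beyond the scatter.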